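A few compounds are considered here, and "the series" means these few. Any claim that something is new, unique, unknown or untested is made for them only; others in the source may bear on it.

Within the data shown here, compound 2 `O=C(Nc1cccc(CN2CCCC2)c1)Nc1ccc2ncnc(Nc3cccc(C(F)(F)F)c3)c2c1` stands at the lower of the two numbers so far in a functional assay on A-431 cells (Homo sapiens) for antiproliferative activity, read by MTT assay, with a stated time of 72 h (on this read-out lower numbers stand for stronger inhibition and higher numbers for weaker inhibition), where compound 2 gives 1230 nM; compound 1 `CCN(CC)Cc1ccc(NC(=O)Nc2ccc3ncnc(Nc4cccc(C(F)(F)F)c4)c3c2)cc1` gives 3980 nM, and the step of a 3.2-fold lower number from compound 1 to compound 2 (0.51 log units; beyond the scatter) separates them. Compound 3 `Cc1ccc(NC(=O)Nc2ccc3ncnc(Nc4cccc(C(F)(F)F)c4)c3c2)cc1` is not yet measured. Relative to compound 2 it carries 4-methylphenyl in place of 3-((pyrrolidin-1-yl)methyl)phenyl on an amide-type nitrogen. Among the measured compounds shown here, the one measured step, a 3.2-fold lower number from compound 1 to compound 2 (0.51 log units; beyond the scatter), exchanges one substituted phenyl for another on the same amide-type nitrogen, both retaining an amine; the change to compound 3 instead drops the 3-((pyrrolidin-1-yl)methyl)phenyl for 4-methylphenyl, so that step bears on it only loosely and gives no direction. For the measured compounds named here, with nothing measured that points either way, compound 3 is expected to land between the two known numbers, a step of a 2.0-fold higher number from compound 2 to compound 3 (0.31 log units; beyond the scatter) that could fall on either side of the scatter. The estimate for compound 3 in this assay is 2500 nM, with a range from 600 nM to 10000 nM.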

Compound 3, half-maximal inhibitory concentration: > 10000 nM
Compound 3: a limit, no number (the forecaster's own chance of this, stated with the estimate: 5%); at least 4.0-fold (0.60 log units) between middle value and limit.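

In this assay compound 3 reads as a limit and not a number: the limit of > 10000 nM in this assay, at which 1 of the 3 values shown sits. With 4-methylphenyl on the amide-type nitrogen, the series moves by an at least 8.1-fold higher number from compound 2 to compound 3 (0.91 log units; beyond the scatter), and removing only the diethylamino group gives an at least 2.5-fold higher number from compound 1 to compound 3 (0.40 log units; beyond the scatter). Among these three compounds, the two with an amine on this substituent give numbers and the one without gives only the limit, with none going against this, though three compounds carry the pattern only thinly.

The two amine-bearing groups differ in both the amine and the place on the phenyl, so the contribution of each remains unresolved. As far as these compounds go, how a morpholine, a primary amine, a carboxylic acid or a longer chain carrying the pyrrolidine would read on this nitrogen's phenyl also stays open.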